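Working notes: iodo for piperazin-1-yl, tolerability on Vero cells

A few compounds are considered here, and "the series" means these few. Any claim that something is new, unique, unknown or untested is made for them only; others in the source may bear on it.

Compound 1 `O=C(/C=C/c1ccc([N+](=O)[O-])o1)c1ccc(N2CCNCC2)cc1` was tested in an ADME assay on Vero cells (Chlorocebus sabaeus) for cytotoxicity, read by resazurin assay, with a stated time of 72 h; a lower number here means that less compound is tolerated, a higher number that more compound is tolerated. Compound 1 gives only a limit there, > 100000 nM, and not a number. Going by the values given here, this is the limit (the limit of > 100000 nM in this assay, at which 1 of the 3 values shown sits), and compound 1 is the sole compound of the three resting on it. Compound 2 `Cc1ccccc1C(=O)/C=C/c1ccc([N+](=O)[O-])o1` gives a number in this assay, namely 41300 nM. Compound 3 `O=C(/C=C/c1ccc([N+](=O)[O-])s1)c1ccc(C2CCCCC2)cc1` carries "not determined" (no result reported) in this assay, so no value is available for it. Among the compounds with values here, no two measured compounds differ in a single place, so no measured step is available.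

Compound 4 `O=C(/C=C/c1ccc([N+](=O)[O-])o1)c1ccc(I)cc1` remains to be measured. It differs from compound 1 by iodo in place of piperazin-1-yl on an aromatic carbon. With compound 1 standing at a limit, the size of the step can only be bounded from one side. A downward move beyond the scatter is expected, roughly toward the number that compound 2 gives, 41300 nM. Compound 4 is estimated at 30000 nM in this assay, within 10000 nM to 100000 nM. This estimate implies an expected step of an at least 3.3-fold lower number from compound 1 to compound 4 (0.52 log units; beyond the scatter).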

Compound 4, half-maximal cytotoxic concentration: > 100000 nM
Compound 4 was reported as a limit; the forecaster's own chance of this, stated with the estimate: 30%; at least 3.3-fold (0.52 log units) between middle value and limit.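

Compound 1 and compound 4 both rest on the same limit in this assay, so no step can be read for iodo in place of piperazin-1-yl: the limit of > 100000 nM in this assay, at which 2 of the 4 values shown sit.

The compounds shown leave open where compound 1 and compound 4 lie relative to each other, and whether this exchange shifts tolerability at all.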